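Swapping an amide for a sulfonamide on a pyridine side chain

This account rests on a few compounds, and the source may have more. Where it says the series, first, only, none or still open, it means among the compounds named here.

Compounds measured so far:
compound 1, `CCC(=O)NCc1cncc(N2C(=O)c3ccc(Cl)cc3C2(C)C)c1`, 282 nM
compound 2, `CC(=O)N1CC2(C1)CN(c1cncc(N3C(=O)c4ccc(Cl)cc4C3(C)C)c1)C2`, 23 nM
compound 3, `O=C(Nc1cccnc1)c1ccc(Cl)cc1`, 420 nM

All three were tested in an assay on cells for inhibition of cytochrome P450 11B2, mitochondrial (Homo sapiens), read by HTRF; a lower number here means a stronger inhibitor, a higher number a weaker inhibitor. Compound 1 stands second highest of the three numbers. Its nearest neighbour is compound 3, whose value lies within the usual scatter of compound 1, so the two cannot be told apart. Compound 2 stands furthest away, with a number clearly lower than compound 1, beyond the scatter.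

Compound 4, `CC1(C)c2cc(Cl)ccc2C(=O)N1c1cncc(CNS(C)(=O)=O)c1`, has not yet been measured. It differs from compound 1 in one place: methylsulfonyl in place of propanoyl on an amine nitrogen. The change is small in size, a propanoyl leaving and a methylsulfonyl entering on the same amine nitrogen, so the count of heavy atoms stays the same while the number of hydrogen-bond acceptors rises.

Going by the values given here, no measured pair shows what this kind of swap does here. In this assay the step from compound 1 to compound 4 is expected to be a 1.1-fold lower number from compound 1 to compound 4 (0.04 log units; within the scatter), that is, no move beyond the scatter in either direction. Compound 4 is therefore estimated at 260 nM, with a range from 90 nM to 750 nM.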

Compound 4, half-maximal inhibitory concentration: 33 nM
Compound 4: middle estimate off by 7.9-fold (0.90 log units), on the high side; the whole stated range lies above it.
By their numbers in this assay, from the lowest: compounds 2 and 4 (each within the scatter of the next); then compounds 1 and 3 (each within the scatter of the next).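

Putting methylsulfonyl in place of propanoyl on this amine nitrogen, with the heavy-atom count unchanged, gives an 8.5-fold lower number from compound 1 to compound 4 (0.93 log units; beyond the scatter) in this assay. Going by these compounds alone, no earlier pair differed in one place, so this is the first direct sign that the group on this nitrogen strongly affects the number, and that two groups of equal heavy-atom count can behave very differently here. Nothing at hand explains why the step is this large.

The compounds shown do not separate the sulfonyl unit from the smaller carbon count of the methylsulfonyl group: an acetyl or an ethylsulfonyl on the same nitrogen would pull these two apart. Also open, on these data alone, is how a urea or a methyl on the sulfonamide nitrogen would read.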